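One Carbon Added on the Chain at the Carbonyl Oxygen

This account rests on a few compounds, and the source may have more. Where it says the series, first, only, none or still open, it means among the compounds named here.

Compound 2 `CCOC(=O)N1CCN(C(=O)c2nc(Nc3cc(C4CC4)[nH]n3)c3cc(Cl)ccc3n2)C[C@H]1C` was tested in an assay for inhibition of serine/threonine-protein kinase PAK 4 (Homo sapiens), read by FRET and Z'-LYTE, with a stated time of 60 min, tested at 5 uM, in the presence of a further agent that is not named here (on this read-out lower numbers stand for a weaker effect and higher numbers for a stronger effect at the one concentration tested), and gave 79.2%. Among the compounds with values here, of the two numbers measured so far it stands highest, yet the nearest number, that of compound 1 `C[C@@H]1CN(C(=O)c2nc(Nc3cc(C4CC4)[nH]n3)c3cc(Cl)ccc3n2)CCN1C(=O)OCc1ccccc1` with 74%, lies within the scatter, so no order can be set between the two. Within the data shown here, the single measured step, a number 5.2 percentage points higher from compound 1 to compound 2 (within the scatter), changed the group on the same saturated chain carbon bound to an oxygen next to a carbonyl group and stayed within the scatter. Compound 3 `CC(C)OC(=O)N1CCN(C(=O)c2nc(Nc3cc(C4CC4)[nH]n3)c3cc(Cl)ccc3n2)C[C@H]1C` differs from compound 2 by methyl in place of hydrogen on a saturated chain carbon bound to an oxygen next to a carbonyl group and a saturated chain carbon; cut one bond further out this reads ethyl to isopropyl. Among the measured compounds shown here, the step of a number 5.2 percentage points higher from compound 1 to compound 2 (within the scatter) was a larger exchange at this place and stayed within the scatter, which is the only guide available. Compound 3 is therefore expected to stay within the scatter of compound 2, an expected step of a number 1.2 percentage points lower from compound 2 to compound 3 (within the scatter). Compound 3 is estimated at 78%, between 64% and 90%.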

Compound 3, a percentage reported as inhibition, at one concentration (the size of the read-out at that concentration, not a potency): 75.8%
Estimate against measurement, compound 3: 2.2 percentage points above, and the stated range covers the measured number.
By their numbers in this assay, from the lowest: compounds 1, 3 and 2 (each within the scatter of the next).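

In this assay the exchange of ethyl to isopropyl, a methyl in place of hydrogen on a saturated chain carbon bound to an oxygen next to a carbonyl group and a saturated chain carbon, gave a number 3.4 percentage points lower from compound 2 to compound 3 (within the scatter) and so showed that this added carbon leaves the read-out within the scatter. Isopropyl in place of benzyl on an oxygen next to a carbonyl group gave a number 1.8 percentage points higher from compound 1 to compound 3 (within the scatter) and so benzyl, ethyl and isopropyl at this place now stand together with no order among them. Nothing measured here explains why these exchanges stay within the scatter.

The compounds shown leave open whether a tert-butyl group, a longer chain or a chain bearing an amine on this oxygen would move the number beyond the scatter. As far as these compounds go, each number also comes from a single concentration, so it tells only the size of the effect at that concentration, and how the three compounds would compare at other concentrations remains open.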